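This account rests on a few compounds, and the source may have more. Where it says the series, first, only, none or still open, it means among the compounds named here.

Three compounds share one core and differ only in the group carried on a saturated chain carbon bound to the outer aromatic ring. Compound 1 `CCCCOC(=O)NS(=O)(=O)c1sc(CC(C)C)cc1-c1ccc(CN2CCN(C)C2=O)cc1` gives 16.5 nM in an assay on membranes from uterus for displacement of a labelled ligand from Angiotensin type II receptor (Sus scrofa), with a stated time of 1.5 h; on this read-out higher numbers stand for weaker inhibition and lower numbers for stronger inhibition. Compound 2 `CCCCOC(=O)NS(=O)(=O)c1sc(CC(C)C)cc1-c1ccc(Cn2cnc(C(F)(F)F)c2)cc1` gives 7.3 nM, and compound 3 `CCCCOC(=O)NS(=O)(=O)c1sc(CC(C)C)cc1-c1ccc(Cc2nnc(C(F)(F)F)o2)cc1` gives 328 nM. Compound 2 stands lowest of the three: the step of a 2.3-fold lower number from compound 1 to compound 2 (0.35 log units; beyond the scatter) is modest, while a 20-fold higher number from compound 1 to compound 3 (1.30 log units; beyond the scatter) and a 45-fold higher number from compound 2 to compound 3 (1.65 log units; beyond the scatter) are large.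

Compound 4 `CCCCOC(=O)NS(=O)(=O)c1sc(CC(C)C)cc1-c1ccc(C(=O)c2ccnn2C)cc1` is not yet measured. Compared with compound 2 it differs by a group of 8 heavy atoms (5 carbon, 2 nitrogen, 1 oxygen; one five-membered aromatic ring with 2 hetero atoms) in place of a group of 10 heavy atoms (5 carbon, 2 nitrogen, 3 fluorine; one five-membered aromatic ring with 2 hetero atoms), on an aromatic carbon. Among the measured compounds shown here, no measured step matches this change, since the chain carbon itself is replaced by a carbonyl and the ring swapped. The steps to compound 3 show that changing the ring in this position can cost a great deal, while the step from compound 1 to compound 2 shows a small gain is also possible. A weaker result than compound 2, of moderate size, is therefore expected, as a 4.1-fold higher number from compound 2 to compound 4 (0.61 log units; beyond the scatter). Compound 4 is estimated at 30 nM, within 8 nM to 120 nM.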

Compound 4, inhibition constant: 3.4 nM
Beside the measured number, compound 4's estimate is 8.8-fold (0.95 log units) above it, and the stated range ends above it.
By their numbers in this assay, from the lowest: compound 4; then compound 2; then compound 1; then compound 3.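

In this assay compound 4 gives the lowest number of the four, with all three steps beyond the scatter (a 2.1-fold lower number from compound 2 to compound 4 (0.33 log units; beyond the scatter); a 4.9-fold lower number from compound 1 to compound 4 (0.69 log units; beyond the scatter); a 96-fold lower number from compound 3 to compound 4 (1.98 log units; beyond the scatter)). This position therefore accepts a carbonyl in place of the saturated chain carbon, and a low number is reached here with no trifluoromethyl on the five-membered ring. No measurement shown here explains this result.

On these data alone, the carbonyl and the ring changed together, so the share of each in the step remains unknown; a 1-methyl-1H-pyrazol-5-yl ring on a saturated chain carbon would separate them. Also open, as far as these compounds go, is whether other groups on the carbonyl, such as a phenyl ring or a dimethylamino group, would keep this low number.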